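Cyclopropyl in place of 1H-benzimidazol-2-yl

This account rests on a few compounds, and the source may have more. Where it says the series, first, only, none or still open, it means among the compounds named here.

In an ADME assay on GES1 cells (Homo sapiens) for inhibition, read by MTT assay, with a stated time of 72 h (on this read-out lower numbers stand for stronger inhibition and higher numbers for weaker inhibition), compound 3 `Cc1cc(Nc2cc(-c3ccccc3)[nH]n2)n2nc(SCc3nc4ccccc4[nH]3)nc2n1` gives 27800 nM and compound 2 `Cc1cc(Nc2cc(-c3ccccc3)[nH]n2)n2nc(SCC(=O)c3ccccc3)nc2n1` gives 33300 nM, with a 1.2-fold lower number from compound 2 to compound 3 (0.08 log units; within the scatter). Compound 1 `Cc1cc(Nc2cc(-c3ccccc3)[nH]n2)n2nc(SCC3CCCCC3)nc2n1` gives > 50000 nM, which is a limit of the assay. Compound 4 `Cc1cc(Nc2cc(-c3ccccc3)[nH]n2)n2nc(SCC3CC3)nc2n1` carries cyclopropyl in place of 1H-benzimidazol-2-yl on a saturated chain carbon bound to a sulfur. The closest measured change is the cyclohexyl one read in reverse, an at least 1.7-fold lower number from compound 1 to compound 3 (0.25 log units; that floor lies within the scatter); an at least 1.5-fold lower number from compound 1 to compound 2 (0.17 log units; that floor lies within the scatter) also offers only a floor. A modest move to a higher number is therefore expected in this assay, and it may reach the limit. The expected step is a 1.5-fold higher number from compound 3 to compound 4 (0.18 log units; within the scatter). For compound 4 the estimated value is 42000 nM, with an expected range of 22000 nM to 75000 nM.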

Compound 4, half-maximal inhibitory concentration: > 50000 nM
Compound 4: only a limit was reported; the forecaster's own chance of this, stated with the estimate: 40%; middle value at least 1.1-fold (0.07 log units) from the limit.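

Compound 4, like compound 1, stands at a limit and not at a number: the limit of > 50000 nM in this assay, at which 2 of the 4 values shown sit. In this assay, cyclopropyl therefore joins cyclohexyl as a saturated ring without a readable value, while benzoyl and 1H-benzimidazol-2-yl, the two groups with an aromatic ring, give numbers. The floors of both steps (an at least 1.7-fold higher number from compound 3 to compound 4 (0.25 log units; that floor lies within the scatter) and an at least 1.5-fold higher number from compound 2 to compound 4 (0.17 log units; that floor lies within the scatter)) lie within the scatter, and the step between compound 1 and compound 4 cannot be read.

From the compounds shown here alone, how far compound 1 and compound 4 lie past the limit remains open. So does whether an amine, a carboxylic acid or a longer chain on this carbon would give a readable number.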